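Trifluoromethyl in place of hydroxy on the aryl ring

A few compounds are considered here, and "the series" means these few. Any claim that something is new, unique, unknown or untested is made for them only; others in the source may bear on it.

Of the compounds shown here, three built on one shared core have been measured in an assay on CHO cells for inhibition of Glucagon receptor (Homo sapiens), tested at 20 uM; on this read-out higher numbers stand for more inhibition at the one concentration tested (going by the name of the read-out) and lower numbers for less inhibition. Compound 1 `CCCCCc1c(C(C)C)nc(C(C)C)c(CO)c1-c1ccc(OC)cc1` carries a methoxy group on its aromatic ring, and in this assay compound 1 gives 37%. Compound 2 `CCCCCc1c(C(C)C)nc(C(C)C)c(CO)c1-c1ccc(CC)cc1` carries an ethyl group in that position, and in this assay compound 2 gives 42%. Compound 3 `CCCCCc1c(C(C)C)nc(C(C)C)c(CO)c1-c1ccc(O)cc1` carries a hydroxy group, and in this assay compound 3 gives 24%, the lowest of the three numbers. The steps between them are a number 5 percentage points higher from compound 1 to compound 2 (within the scatter), a number 13 percentage points lower from compound 1 to compound 3 (beyond the scatter) and a number 18 percentage points lower from compound 2 to compound 3 (beyond the scatter).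

Compound 4 `CCCCCc1c(C(C)C)nc(C(C)C)c(CO)c1-c1ccc(C(F)(F)F)cc1` has not been measured. It differs from compound 3 in one place: trifluoromethyl in place of hydroxy on an aromatic carbon. Within the data shown here, the steps that bear on this change are a number 18 percentage points lower from compound 2 to compound 3 (beyond the scatter) and a number 13 percentage points lower from compound 1 to compound 3 (beyond the scatter), both modest and both pointing down toward the hydroxy compound. Read the other way, exchanging the hydroxy group for a group with no hydrogen-bond donor and no hydrogen-bond acceptor is expected to lift the number beyond the scatter. Compound 4 is therefore expected to show a rise of a number 16 percentage points higher from compound 3 to compound 4 (beyond the scatter) in this assay. The estimate for compound 4 in this assay is 40%, with a range from 25% to 55%.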

Compound 4, a percentage reported as inhibition, at one concentration (the size of the read-out at that concentration, not a potency): 35%
Beside the measured number, compound 4's estimate is 5 percentage points above it, and the stated range covers the measured number.
By their numbers in this assay, from the lowest: compound 3; then compounds 4, 1 and 2 (each within the scatter of the next).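

In this assay, the step of a number 11 percentage points higher from compound 3 to compound 4 (beyond the scatter) shows that hydroxy's low number also holds against a third group on this aromatic carbon, not only against methoxy and ethyl. The steps of a number 7 percentage points lower from compound 2 to compound 4 (within the scatter) and of a number 2 percentage points lower from compound 1 to compound 4 (within the scatter) leave trifluoromethyl inseparable from ethyl and methoxy, so among the four groups only hydroxy stands apart at this position, while the other three cannot be ranked in this read-out. No measurement at hand accounts for the separation of hydroxy from the other three groups.

The compounds shown leave open whether a group such as an amine, a carboxylic acid or a longer chain like butyl on this aromatic carbon would fall with hydroxy, sit with the other three groups or rise clear of them. Each number also comes from a single concentration, so they leave open how these compounds compare in potency, and whether the gap between hydroxy and trifluoromethyl would persist across a full concentration range.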